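Swapping an Oxadiazole for an Oxime Ether in a Cytotoxicity Series

The source may report more compounds than this note shows. Statements on the series, on what has been measured and on what is new or still open speak of the compounds shown alone.

Of the compounds shown here, three on a shared core have been tested in an ADME assay on RD cells (Homo sapiens) for cytotoxicity, read by MTT assay, with a stated time of 24 h; a lower number here means that less compound is tolerated, a higher number that more compound is tolerated. Compound 1, `CCc1nc(-c2cc(C)c(OCCC(C)CCN3CCN(c4ccnc(N)c4)C3=O)c(C)c2)no1`, gives 15700 nM in this assay, the lowest of the two numbers that were read. Compound 3, `CC(CCOc1ccc(-c2noc(C(F)(F)F)n2)cc1)CCN1CCN(c2ccnc(N)c2)C1=O`, gives 48100 nM, a higher number that sits beyond the usual scatter. Compound 2, `CCO/N=C/c1ccc(OCCC(C)CCN2CCN(c3ccccc3)C2=O)cc1`, reaches only the assay limit of > 100000 nM, so no number is known for it; (the limit of > 100000 nM in this assay, at which 1 of the 3 values shown sits).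

The next step keeps the core of compound 1 and changes one group: compound 4, `CCO/N=C/c1cc(C)c(OCCC(C)CCN2CCN(c3ccnc(N)c3)C2=O)c(C)c1`, differs from compound 1 by a group of 5 heavy atoms (3 carbon, 1 nitrogen, 1 oxygen; no ring) in place of a group of 7 heavy atoms (4 carbon, 2 nitrogen, 1 oxygen; one five-membered aromatic ring with 3 hetero atoms), on an aromatic carbon. The 5-ethyl-1,2,4-oxadiazol-3-yl group leaves and a group without a ring, carrying one double bond outside aromatic rings, enters on an aromatic carbon.

Compound 2 already carries this entering group and tolerates the highest dose, though it also lacks the two methyl groups and the amino-substituted ring. Compound 4 is therefore expected to give 40000 nM, within 15000 nM to 100000 nM. The expected step is a 2.5-fold higher number from compound 1 to compound 4 (0.41 log units; beyond the scatter), a rise beyond the scatter, toward more compound being tolerated.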

Compound 4, half-maximal cytotoxic concentration: 12900 nM
Compound 4: middle estimate off by 3.1-fold (0.49 log units), on the high side, and the stated range ends above it.
By their numbers in this assay, from the lowest: compounds 4 and 1 (each within the scatter of the next); then compound 3. At a limit, above all of these: compound 2.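

Swapping the 5-ethyl-1,2,4-oxadiazol-3-yl group for the oxime ether gives a 1.2-fold lower number from compound 1 to compound 4 (0.09 log units; within the scatter) in this assay, so on this core the two compounds cannot be told apart. Going by these compounds alone, at this position, para to a large group and meta to two methyl groups, the five-membered aromatic ring can therefore be exchanged for a group with no ring without a reading beyond the scatter, which no earlier pair could show, since no two earlier compounds differed in one place. Nothing measured here explains why these two groups read alike.

On these data alone, whether a different group at this position, such as an amine, a carboxylic acid or a longer chain, would shift the number remains open. So does the separate contribution of the two methyl groups and of the amino-substituted ring.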